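From pyridin-3-yl to 1,3-benzoxazol-5-yl: a clearance forecast

The source may hold more compounds than are shown below. What is called first, only, known or untested is meant among the compounds shown, and "the series" means these compounds.

In an ADME assay (liver) for metabolic stability, with Liver microsome (Rattus norvegicus) as the target, using microsomes and NADPH, with a stated time of 30 min, tested at 1 uM (on this read-out lower numbers stand for slow clearance and higher numbers for fast clearance), compound 3 `Nc1ccc(S(=O)(=O)N2CCN(c3ncc(C(O)(C(F)(F)F)C(F)(F)F)cc3-c3cccnc3)CC2)cn1` gives 20 mL.min-1.g-1 as the lowest of three numbers. Within the data shown here, compound 1 `Nc1ccc(S(=O)(=O)N2CCN(c3ncc(C(O)(C(F)(F)F)C(F)(F)F)cc3-c3ccoc3)CC2)cn1` gives 57 mL.min-1.g-1 and compound 2 `Cc1csc(-c2cc(C(O)(C(F)(F)F)C(F)(F)F)cnc2N2CCN(S(=O)(=O)c3ccc(N)nc3)CC2)c1` gives 399 mL.min-1.g-1 with only one group changed on the shared core. Compound 4 `Nc1ccc(S(=O)(=O)N2CCN(c3ncc(C(O)(C(F)(F)F)C(F)(F)F)cc3-c3ccc4ocnc4c3)CC2)cn1` carries 1,3-benzoxazol-5-yl in place of pyridin-3-yl on an aromatic carbon on that same aromatic carbon. Among the measured compounds shown here, two measured steps bear on this swap, as a 2.9-fold lower number from compound 1 to compound 3 (0.45 log units; beyond the scatter) counts as modest and a 20-fold lower number from compound 2 to compound 3 (1.30 log units; beyond the scatter) counts as large, and both end at pyridin-3-yl. Leaving pyridin-3-yl is therefore expected to raise the number, and a 3.5-fold higher number from compound 3 to compound 4 (0.54 log units; beyond the scatter) is the estimated step in this assay for this swap. The estimate for compound 4 is 70 mL.min-1.g-1 with 25 mL.min-1.g-1 to 200 mL.min-1.g-1 as the expected range.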

Compound 4, intrinsic clearance in microsomes: 120 mL.min-1.g-1
Compound 4: the middle estimate sits 1.7-fold (0.23 log units) below what was measured; measured number inside the range.
By their numbers in this assay, from the lowest: compound 3; then compound 1; then compound 4; then compound 2.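

In this assay, a fused two-ring group at this position gives a 6.0-fold higher number from compound 3 to compound 4 (0.78 log units; beyond the scatter) and so leaves pyridin-3-yl with the lowest number of the four groups. Compound 4 also falls between the two earlier five-membered rings: 4-methylthiophen-2-yl stands well above it, with a 3.3-fold lower number from compound 2 to compound 4 (0.52 log units; beyond the scatter) as the step, while furan-3-yl stands below it, with a 2.1-fold higher number from compound 1 to compound 4 (0.32 log units; beyond the scatter) as the step. Nothing available here explains why the groups fall in this order. From the compounds shown here alone, whether an amine or a carboxylic acid on the pyridin-3-yl ring would shift the number remains open.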